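Moving a Methyl Group on a Pyridine Ring

The compounds below may be only part of what the source reports. "The series", "measured", "known", "first", "only" and "open" are said of these compounds alone.

Of the compounds shown here, three built around the same thiosemicarbazone core have been tested in a functional assay on A-431 cells (Homo sapiens) for cytotoxicity, read by MTT assay, with a stated time of 72 h, tested at 1 uM; on this read-out higher numbers stand for more inhibition of growth at the one concentration tested and lower numbers for less inhibition of growth. Compound 1 `Cc1cccc(/C(N)=N/NC(=S)N2CCN(c3ccccn3)CC2)n1` gives 9.2% in this assay. Compound 2 `N/C(=N\NC(=S)N1CCCCCC1)c1ccccn1` gives 18.8%, a number that lies within the usual scatter of the number for compound 1, so the two cannot be told apart. Compound 3 `N/C(=N\NC(=S)N1CCOCC1)c1ccccn1` gives 29.2%, and here the gap to compound 1 is beyond the scatter, with compound 3 the higher of the two. Compound 1 thus sits at the low end of the three numbers.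

Compound 4 `Cc1ccnc(/C(N)=N/NC(=S)N2CCN(c3ccccn3)CC2)c1` has the same atoms as compound 1 joined differently: 4-methylpyridin-2-yl in place of 6-methylpyridin-2-yl on a carbon with a double bond to nitrogen. Going by the values given here, no pair of measured compounds shows such a change, so nothing directly tells how much a shift of the methyl group matters. The step from compound 1 to compound 4 is expected to be small, a number 2.8 percentage points higher from compound 1 to compound 4 (within the scatter), not beyond the scatter in either direction. Compound 4 is therefore estimated to give 12% in this assay, with a range from 0% to 28%.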

Compound 4, percent growth inhibition at one concentration: 28.9%
Estimate against measurement, compound 4: 16.9 percentage points below; measured number above the stated range.
By their numbers in this assay, from the lowest: compounds 1 and 2 (each within the scatter of the next); then compounds 4 and 3 (each within the scatter of the next).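

In this assay, going by these compounds alone, 4-methylpyridin-2-yl in place of 6-methylpyridin-2-yl on this carbon gives a number 19.7 percentage points higher from compound 1 to compound 4 (beyond the scatter) and so shows what the earlier compounds could not: moving the methyl group alone can change the number by more than the usual scatter. The two groups have the same heavy atoms, hydrogen-bond donors and acceptors, so those counts do not distinguish them, and the difference lies only in how the atoms are joined. Nothing available here explains why this shift raises growth inhibition.

Going by these compounds, whether the effect belongs to the methyl group itself remains open, as an ethyl group, a chlorine atom or an amine in the same place on the pyridine ring could give a different number. The step also comes from one concentration in one cell line, so it says nothing yet about how the two compounds compare across a range of concentrations.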